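Swapping the Aryl Group on Sulfur in a Benzamide Series

The source may hold more compounds than are shown below. What is called first, only, known or untested is meant among the compounds shown, and "the series" means these compounds.

Compound 2 `Cc1cc(C)cc(SCc2ccc(C(=O)Nc3ccccc3N)cc2)c1` and compound 1 `Nc1ccccc1NC(=O)c1ccc(CSc2cccc(F)c2)cc1` share one core and differ only in the aryl group on the sulfur. In a functional assay on HeLa cells (Homo sapiens) for antiproliferative activity, read by CCK-8 assay, with a stated time of 72 h (a higher number here means a weaker inhibitor, a lower number a stronger inhibitor), compound 2 gives 2090 nM, while compound 1 gives 3240 nM; the step of a 1.6-fold lower number from compound 1 to compound 2 (0.19 log units; within the scatter) is within the scatter, so the two stand side by side. Compound 3 `Nc1ccccc1NC(=O)c1ccc(CSc2ccc(F)cc2)cc1` carries 4-fluorophenyl in place of 3,5-dimethylphenyl on a sulfur. Among the measured compounds shown here, the only measured step that bears on this change is the one from compound 1 to compound 2, and it was small, so no step beyond the scatter is expected here. For compound 3 the estimate is 2800 nM (range 1200 nM to 6500 nM), meaning an expected step of a 1.3-fold higher number from compound 2 to compound 3 (0.13 log units; within the scatter).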

Compound 3, half-maximal inhibitory concentration: 5010 nM
The estimate for compound 3 lay 1.8-fold (0.25 log units) below the measured number, and the stated range covers the measured number.
By their numbers in this assay, from the lowest: compounds 2, 1 and 3 (each within the scatter of the next, the first and the last beyond it).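

In this assay, 4-fluorophenyl in place of 3,5-dimethylphenyl on the sulfur gives a 2.4-fold higher number from compound 2 to compound 3 (0.38 log units; beyond the scatter), so the aryl group at this position can move the number beyond the scatter, if only modestly. By contrast, 4-fluorophenyl in place of 3-fluorophenyl gives a 1.5-fold higher number from compound 1 to compound 3 (0.19 log units; within the scatter), so the two fluorophenyl groups cannot be told apart here. Nothing available explains the difference between the dimethylphenyl and fluorophenyl compounds.

Still open, on these data alone, is whether a single methyl group would behave like the two in compound 2. How an aryl group carrying an amine or a carboxylic acid would read is also unknown.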